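The source may hold more compounds than are shown below. What is called first, only, known or untested is meant among the compounds shown, and "the series" means these compounds.

Measured compounds:
- Compound 1, `CS(=O)(=O)Nc1cccc2c1CCCCC2c1c[nH]cn1`: 4.72
- Compound 2, `O=S(=O)(Nc1cccc2c1CCCC2c1c[nH]cn1)C1CC1`: 5.25

Both compounds were tested in a functional assay on Urethra for agonist activity at Alpha-1A adrenergic receptor (Oryctolagus cuniculus); on this read-out higher numbers stand for higher potency (the scale is a negative logarithm) and lower numbers for lower potency. Compound 2 gives the higher of the two numbers, and compound 1 sits a step lower that lies beyond the usual scatter; as the two structures differ in more than one place, nothing more can be read from that pair than the values themselves show.

Compound 3, `CC(=O)Nc1cccc2c1CCCC2c1c[nH]cn1`, has not yet been measured. It keeps the core of compound 2 and changes only the group on the ring nitrogen: acetyl in place of cyclopropylsulfonyl on a nitrogen on an aromatic ring. Going by the values given here, no measured pair in this set shows what that particular exchange does, so the expectation rests on the standing of compound 2 alone and carries a wide margin.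

The change from compound 2 to compound 3 is expected to cost potency, by a step of a number 0.65 log units lower from compound 2 to compound 3 (beyond the scatter), but not more than the scatter would make hard to distinguish from a flat result.

Compound 3 is accordingly estimated at 4.6 in this assay, with a likely range from 4 to 5.3.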

Compound 3, negative logarithm of the half-maximal effective concentration: 5.89
Compound 3: the middle estimate sits 1.29 log units below what was measured, outside the stated range (above it).
By their numbers in this assay, from the lowest: compound 1; then compound 2; then compound 3.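

In this assay, putting acetyl in place of cyclopropylsulfonyl on a nitrogen on an aromatic ring gives a step of a number 0.64 log units higher from compound 2 to compound 3 (beyond the scatter), so the group on this nitrogen clearly affects the read-out, and a sulfonyl group is not required there for agonist activity. Going by these compounds alone, this is the first pair in the set that differs in one place only, and so the first direct reading of this position; compound 1 differs from compound 2 and compound 3 in more than one place and adds nothing to it. The change removes a sulfur, a three-membered ring and several heavy atoms all at once, and nothing available here says which of these matters or why the step occurs.

Cyclopropylcarbonyl on the same nitrogen would keep the three-membered ring while replacing the sulfonyl with a carbonyl, so it could help separate the part played by the ring from that of the sulfonyl. Also open, going by these compounds, is how a longer chain such as propanoyl, or a plain amine at this place, would compare with acetyl on the same core.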